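From a Pyridinyl Amide to a Chlorophenyl Amide

A few compounds are considered here, and "the series" means these few. Any claim that something is new, unique, unknown or untested is made for them only; others in the source may bear on it.

Compound 1 `CC1=C(C(=O)NC2CCCCC2)C(c2ccccc2)NC(=O)N1`: > 100000 nM. Compound 2 `CC1=C(C(=O)Nc2ccccc2Cl)C(c2cccc(Br)c2)NC(=O)N1`: > 100000 nM. Compound 3 `CC1=C(C(=O)Nc2ccccn2)C(c2cccs2)NC(=O)N1`: > 100000 nM.

All three values come from an ADME assay on Vero cells (Chlorocebus sabaeus) for cytotoxicity, read by XTT assay, with a stated time of 72 h; on this read-out higher numbers stand for lower toxicity in this test and lower numbers for higher toxicity in this test. The value of compound 1 in this assay is a limit of the assay, not a number. The value of compound 2 is likewise a limit. For compound 3 the value is again a limit, and no number is known for it; it sits together with the two other compounds at the same limit, as stated in the limit of > 100000 nM in this assay, at which 3 of the 3 values shown sit. Going by the values given here, no step between two measured compounds is available, since none of the three differs from another in only one place.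

Compound 4 `CC1=C(C(=O)Nc2cccc(Cl)c2)C(c2cccs2)NC(=O)N1` has not been measured in this assay. It differs from compound 3 by 3-chlorophenyl in place of pyridin-2-yl on an amide-type nitrogen. The three measured compounds share the limit, and the expectation for this change is no step beyond the scatter, with the estimated step that the limit leaves unreadable from compound 3 to compound 4. Compound 4 is therefore expected to give about 150000 nM, within 50000 nM to 500000 nM.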

Compound 4, half-maximal cytotoxic concentration: > 100000 nM
Compound 4 ended at the assay's limit (the forecaster's own chance of this, stated with the estimate: 85%); the middle value does not contradict the limit.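

No step can be read from compound 3 to compound 4, since both values are limits: the limit of > 100000 nM in this assay, at which 4 of the 4 values shown sit.

The compounds shown leave open what 3-chlorophenyl in place of pyridin-2-yl on an amide-type nitrogen does to the half-maximal cytotoxic concentration in this assay.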